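Chain homologation in a flavone series

The source may report more compounds than this note shows. Statements on the series, on what has been measured and on what is new or still open speak of the compounds shown alone.

Compound 1 `O=c1cc(-c2ccccc2)oc2cccc(OCCCN3CCC(O)CC3)c12` gives 91 nM in an assay on isolated protein (Cavia porcellus) with Sigma non-opioid intracellular receptor 1 (Homo sapiens) as the target, read by radioligand binding; on this read-out higher numbers stand for weaker inhibition and lower numbers for stronger inhibition. Its nearest neighbour, compound 2 `O=c1cc(-c2ccccc2)oc2cccc(OCCCCN3CCC(O)CC3)c12`, gives 177 nM in this assay, and the step of a 1.9-fold higher number from compound 1 to compound 2 (0.29 log units; within the scatter) lies within the scatter. Going by the values given here, on the two numbers known so far, compound 2 stands within the scatter of the only other compound, so no ordering between the two can be claimed.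

Compound 3 `O=c1cc(-c2ccccc2)oc2cccc(OCCCCCCCN3CCC(O)CC3)c12` differs from compound 2 by a further extension of the same chain: 3-(4-hydroxypiperidin-1-yl)propyl in place of 4-hydroxypiperidin-1-yl on a saturated chain carbon, four bonds along the chain from an oxygen on an aromatic ring. Among the compounds with values here, the only step that bears on this change is the earlier lengthening from compound 1 to compound 2, which gave a modest rise in the number that stayed within the scatter. Within the data shown here, the present extension adds more chain than that step did, so the expected outcome in this assay is a somewhat higher number than for compound 2, with considerable uncertainty, since only one prior step speaks to it. For compound 3 the estimated step is a 1.6-fold higher number from compound 2 to compound 3 (0.20 log units; within the scatter). Compound 3 is therefore expected to give about 280 nM in this assay, within a range from 80 nM to 1000 nM.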

Compound 3, half-maximal inhibitory concentration: 65 nM
For compound 3 the middle estimate is 4.3-fold (0.63 log units) above the measured one; the measured number lies below the stated range.
By their numbers in this assay, from the lowest: compounds 3, 1 and 2 (each within the scatter of the next, the first and the last beyond it).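

In this assay, going by these compounds alone, further chain extension carries no penalty at this position: a 2.7-fold lower number from compound 2 to compound 3 (0.44 log units; beyond the scatter) is the first step beyond the scatter, and it runs towards a lower number, with 3-(4-hydroxypiperidin-1-yl)propyl in place of 4-hydroxypiperidin-1-yl, four bonds along the chain from an oxygen on an aromatic ring. The earlier hint of a rise with chain length therefore does not hold as a trend: compound 3 goes against it, while compound 1 at 91 nM and compound 3 at 65 nM lie within the scatter of each other, so neither of these two chain lengths can be ranked above the other. No evidence is available on what lies behind this reversal.

Still open, on these data alone, is how the number behaves for chains of intermediate length and for a chain longer than that of compound 3, and whether the lower number persists there. Also open, as far as these compounds go, is whether the 4-hydroxypiperidin-1-yl group matters at the longest chain, which a plain piperidin-1-yl or a morpholin-4-yl group at the chain end would test.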